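The source may report more compounds than this note shows. Statements on the series, on what has been measured and on what is new or still open speak of the compounds shown alone.

Measured compounds and their values in a functional assay on BJAB cells (Homo sapiens) for antiproliferative activity, with a stated time of 4 days; on this read-out lower numbers stand for an effect already at smaller amounts and higher numbers for an effect only at larger amounts of compound:

- compound 1, `Cc1nn(-c2nc(-c3ccc(Cl)c(Cl)c3)c(SC(C)C)s2)c(C(=O)O)c1-c1cccc(F)c1`: 900 nM
- compound 2, `COc1cncc(-c2c(C)nn(-c3nc(-c4ccc(Cl)c(Cl)c4)c(SC(C)C)s3)c2C(=O)O)c1`: 21000 nM
- compound 3, `Cc1cc(Cl)cc(-c2c(C)nn(-c3nc(-c4ccc(Cl)c(Cl)c4)c(SC(C)C)s3)c2C(=O)O)c1`: 663 nM

Compound 3 carries the lowest of the three numbers in this assay. Its distance from compound 1 is small, a 1.4-fold lower number from compound 1 to compound 3 (0.13 log units; within the scatter), and sits within the scatter, so the two cannot be ranked against each other. For the measured compounds named here, its distance from compound 2 is large, a 32-fold lower number from compound 2 to compound 3 (1.50 log units; beyond the scatter), and the same holds for the step of a 23-fold higher number from compound 1 to compound 2 (1.37 log units; beyond the scatter), which separates the one pyridinyl-bearing compound from both carbon-only phenyl variants.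

Compound 4, `Cc1nn(-c2nc(-c3ccc(Cl)c(Cl)c3)c(SC(C)C)s2)c(C(=O)O)c1-c1ccc(Cl)cc1`, has not been measured. It differs from compound 3 in one place: 4-chlorophenyl in place of 3-chloro-5-methylphenyl on an aromatic carbon. Going by the values given here, the only measured step that bears directly on this kind of swap, one carbon-only phenyl ring carrying a halogen replaced by another, is the step from compound 1 to compound 3, a 1.4-fold lower number from compound 1 to compound 3 (0.13 log units; within the scatter), which stayed within the scatter. The large step of a 23-fold higher number from compound 1 to compound 2 (1.37 log units; beyond the scatter) involves a ring with nitrogen and does not apply here. For this assay a step of a 1.2-fold higher number from compound 3 to compound 4 (0.08 log units; within the scatter) is therefore expected, that is no change beyond the scatter, with the number for compound 4 estimated at 800 nM and likely to fall between 300 nM and 2500 nM.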

Compound 4, half-maximal effective concentration: 2500 nM
Compound 4: the middle estimate sits 3.1-fold (0.49 log units) below what was measured, and the stated range covers the measured number.
By their numbers in this assay, from the lowest: compounds 3 and 1 (each within the scatter of the next); then compound 4; then compound 2.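

In this assay the position on the five-membered ring is not indifferent to the choice among carbon-only phenyl rings: a 3.8-fold higher number from compound 3 to compound 4 (0.58 log units; beyond the scatter) and a 2.8-fold higher number from compound 1 to compound 4 (0.44 log units; beyond the scatter), both beyond the scatter, whereas the earlier exchange among such rings, a 1.4-fold lower number from compound 1 to compound 3 (0.13 log units; within the scatter), stayed within it. The 4-chlorophenyl ring therefore stands apart from the 3-fluorophenyl and 3-chloro-5-methylphenyl rings, yet it does not reach the level of the only ring with nitrogen, as an 8.4-fold lower number from compound 2 to compound 4 (0.92 log units; beyond the scatter) shows, so the three carbon-only rings do not form one uniform group and the 5-methoxypyridin-3-yl ring keeps the highest number of the four. Nothing available gives a reason for these differences.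

The exchange from 3-chloro-5-methylphenyl to 4-chlorophenyl moves the chlorine and removes the methyl group at once, and the compounds shown do not separate these two changes. From the compounds shown here alone, a plain 3-chlorophenyl ring would bear on that question, and how a 4-aminophenyl ring would stand in this assay also remains open.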